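Chromone acrylamide series: amide substituent changes on A549 inhibition

A few compounds are considered here, and "the series" means these few. Any claim that something is new, unique, unknown or untested is made for them only; others in the source may bear on it.

Two members of the series have been measured in a functional assay on A549 cells (Homo sapiens) for inhibition, read by MTT assay, with a stated time of 48 h; on this read-out higher numbers stand for weaker inhibition and lower numbers for stronger inhibition. Compound 1 `COc1ccc2c(=O)c(/C=C/C(=O)NCc3ccc(F)cc3)coc2c1` gives only a limit, > 100000 nM. Compound 2 `COc1ccc2c(=O)c(/C=C/C(=O)NCc3ccccc3F)coc2c1` likewise gives only a limit, > 100000 nM. The step from compound 1 to compound 2, a step that the two limits leave unreadable from compound 1 to compound 2, cannot be read because the limit of > 100000 nM in this assay, at which 2 of the 2 values shown sit: both values sit at the same limit, so nothing is known about the size or direction of that change. Compound 2 therefore stands at the limit, with no measurable inhibition shown.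

Compound 3 `COc1ccc2c(=O)c(/C=C/C(=O)Nc3ccccc3C)coc2c1` differs from compound 2 by 2-methylphenyl in place of 2-fluorobenzyl on an amide-type nitrogen. Among the measured compounds shown here, no measured step bears on this change, and the one measured step is itself unreadable. The step from compound 2 to compound 3 is therefore expected to be a number no higher from compound 2 to compound 3 (the limit leaves the size open), with no reading beyond the scatter anticipated. Compound 3 is estimated at 100000 nM, within 30000 nM to 300000 nM, and most likely reported only as a limit.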

Compound 3, half-maximal inhibitory concentration: 23400 nM
Compound 3: middle estimate off by 4.3-fold (0.63 log units), on the high side; measured number below the stated range.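

The amide-type nitrogen now gives the series its first readable change in this assay: 2-methylphenyl in place of 2-fluorobenzyl gives an at least 4.2-fold lower number from compound 2 to compound 3 (0.63 log units; beyond the scatter), and 2-methylphenyl in place of 4-fluorobenzyl gives an at least 4.2-fold lower number from compound 1 to compound 3 (0.63 log units; beyond the scatter). Both steps share one direction, so the two fluorobenzyl amides both read weaker than the 2-methylphenyl amide, whichever fluorine placement is taken. Both steps give only a minimum size, and the step between compound 1 and compound 2 cannot be read, because two of the values sit at one limit: the limit of > 100000 nM in this assay, at which 2 of the 3 values shown sit.

The change replaces the fluorine with a methyl and drops the saturated chain carbon in a single step, so the compounds shown do not separate the two. Either 2-methylbenzyl or 2-fluorophenyl on that nitrogen would tell them apart.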